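Dichloroacetanilides on Bel-7402 Cells: Predicting a Second Chloro

A few compounds are considered here, and "the series" means these few. Any claim that something is new, unique, unknown or untested is made for them only; others in the source may bear on it.

Measured compounds:
Compound 1, `O=C(Nc1ccccc1Cl)C(Cl)Cl`: "not determined" (no result reported)
Compound 2, `O=C(Nc1ccccc1Br)C(Cl)Cl`: 38200 nM
Compound 3, `O=C(Nc1cccc(Cl)c1Cl)C(Cl)Cl`: 180000 nM

Compound 1 stands without a number in a functional assay on Bel-7402 cells (Homo sapiens) for antiproliferative activity, read by MTT assay, with a stated time of 72 h; on this read-out higher numbers stand for weaker inhibition and lower numbers for stronger inhibition; its position can only be read through its neighbours. In this assay compound 2 gives 38200 nM and compound 3 gives 180000 nM, both weak. Compound 4, `O=C(Nc1cc(Cl)ccc1Cl)C(Cl)Cl`, differs from compound 1 by chloro in place of hydrogen on an aromatic carbon. Since compound 1 has no measured value, the size and direction of the step to compound 4 in this assay cannot be sized; the two measured analogues of compound 1 frame the expected range. Compound 4 is expected to give about 80000 nM in this assay, with a plausible range from 20000 nM to 300000 nM.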

Compound 4, half-maximal inhibitory concentration: 18200 nM
For compound 4 the middle estimate is 4.4-fold (0.64 log units) above the measured one; measured number outside the range, below it.
By their numbers in this assay, from the lowest: compound 4; then compound 2; then compound 3.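

No step can be read from compound 4 to compound 1, compound 2 or compound 3 in this assay. The compounds shown leave open whether the added chloro strengthens or weakens inhibition relative to compound 1. No measured evidence bears on this result.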